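Phenyl ester of the acid: expectation for compound 4

A few compounds are considered here, and "the series" means these few. Any claim that something is new, unique, unknown or untested is made for them only; others in the source may bear on it.

Compound 1 `NCc1ccc(C(=O)Nc2ccncc2F)cc1-c1cccc(C(=O)O)c1` carries a free carboxylic acid and a fluorine on the pyridine amide. In an assay on isolated protein for inhibition of Rho-associated protein kinase 2 (Homo sapiens), read by radiometric assay (on this read-out lower numbers stand for stronger inhibition and higher numbers for weaker inhibition), compound 1 gives 55 nM, the highest of the two numbers recorded, with compound 2 the nearest at a step well beyond the scatter. Compound 2 `CCCCCCOC(=O)c1cccc(-c2cc(C(=O)Nc3ccncc3)ccc2CN)c1`, a hexyl ester without the fluorine, gives 22 nM in this assay. Compound 3 `CCOC(=O)c1cccc(-c2cc(C(=O)Nc3ccncc3)ccc2CN)c1`, the ethyl ester, reaches only the limit of the assay, < 1 nM, and no number is known for it. Among the compounds with values here, the one step that can be sized is an at least 22-fold lower number from compound 2 to compound 3 (1.34 log units; beyond the scatter), which is the only reading on how the ester end governs inhibition, and it sits at the limit noted as the limit of < 1 nM in this assay, at which 1 of the 3 values shown sits.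

Compound 4 `NCc1ccc(C(=O)Nc2ccncc2F)cc1-c1cccc(C(=O)Oc2ccccc2)c1` is the phenyl ester of compound 1: phenyl in place of hydrogen on an oxygen next to a carbonyl group. Within the data shown here, no measured pair compares a free acid with its ester, so the fluorinated acid of compound 1 has no direct precedent. The esters of compounds 2 and 3 both give lower numbers than compound 1, so a modest drop is expected, taken as a 2.2-fold lower number from compound 1 to compound 4 (0.34 log units; beyond the scatter). Compound 4 is therefore estimated at 25 nM in this assay, between 4 nM and 150 nM.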

Compound 4, half-maximal inhibitory concentration: 6.2 nM
The estimate for compound 4 lay 4.0-fold (0.61 log units) above the measured number; the range from low to high includes it.
By their numbers in this assay, from the lowest: compound 4; then compound 2; then compound 1. At a limit, below all of these: compound 3.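

Working notes: in this assay the change to phenyl on the oxygen next to a carbonyl group gives an 8.9-fold lower number from compound 1 to compound 4 (0.95 log units; beyond the scatter) with the fluorine kept on both sides, the first pair in the series that sets a free carboxy group against an ester on one core. The earlier step between compound 2 and compound 3 changed only the chain of an ester, so it could not show that phenoxycarbonyl in place of carboxy is tolerated and lowers the number beyond the scatter. Nothing recorded for these compounds gives a cause for this step.

On these data alone, whether the lower number comes from the phenyl ring or from any ester at this place remains open. An ethyl ester or a primary amide on the fluorinated core would separate these two readings.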